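Aryl urea variation on the shared core, compound 3 to compound 4

The source may hold more compounds than are shown below. What is called first, only, known or untested is meant among the compounds shown, and "the series" means these compounds.

In a functional assay on Malme-3M cells (Homo sapiens) for inhibition, read by sulforhodamine B assay, with a stated time of 48 h, tested at 10 uM (a lower number here means a stronger effect, a higher number a weaker effect of the compound at the concentration tested), compound 1 `COc1cc2cc(Oc3ccc(NC(=O)Nc4ccccc4)cc3)c(C)nc2cc1OC` gives 86.4% and compound 2 `COc1cc2cc(Oc3ccc(NC(=O)Nc4ccc(C(F)(F)F)cc4)cc3)c(C)nc2cc1OC` gives 82.9%; the step of a number 3.5 percentage points lower from compound 1 to compound 2 (within the scatter) is small. Compound 3 `COc1cc2cc(Oc3ccc(NC(=O)Nc4cccc(C(F)(F)F)c4)cc3)c(C)nc2cc1OC` gives 7.22%, the lowest of the three numbers, with a number 79.2 percentage points lower from compound 1 to compound 3 (beyond the scatter) and a number 75.7 percentage points lower from compound 2 to compound 3 (beyond the scatter) both beyond the scatter. Compound 4 `COc1cc2cc(Oc3ccc(NC(=O)Nc4ccc(Cl)c(Cl)c4)cc3)c(C)nc2cc1OC` differs from compound 3 by 3,4-dichlorophenyl in place of 3-(trifluoromethyl)phenyl on an amide-type nitrogen. Going by the values given here, no measured step involves a dichlorophenyl group, so only the comparison of compound 2 with compound 3 bears on it, where relocating the trifluoromethyl changed this assay strongly. Because compound 3 sits at 7.22%, the estimate for compound 4 in this assay is 25%, range 3% to 70%. The expected step of a number 17.8 percentage points higher from compound 3 to compound 4 (beyond the scatter) is therefore modest, with wide uncertainty.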

Compound 4, a percentage reported as activity, at one concentration (the size of the read-out at that concentration, not a potency): 14.9%
For compound 4 the middle estimate is 10.1 percentage points above the measured one; low and high end bracket the measured number.
By their numbers in this assay, from the lowest: compounds 3 and 4 (each within the scatter of the next); then compounds 2 and 1 (each within the scatter of the next).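

In this assay the step of a number 7.7 percentage points higher from compound 3 to compound 4 (within the scatter) shows that 3,4-dichlorophenyl and 3-(trifluoromethyl)phenyl cannot be told apart on this amide-type nitrogen, so among the listed compounds the low number is not tied to trifluoromethyl. The gaps to the other two compounds stay large, with a number 68 percentage points lower from compound 2 to compound 4 (beyond the scatter) and a number 71.5 percentage points lower from compound 1 to compound 4 (beyond the scatter) as the steps, and 4-(trifluoromethyl)phenyl remains the substituted group that goes against any general gain over phenyl. No measured evidence bears on the reason for these differences. Still open, on these data alone, is whether a single chlorine on this aryl ring gives the same result, and whether an amine or a carboxylic acid there keeps it.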